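Swapping a Bulky Amine Substituent for Methyl

A few compounds are considered here, and "the series" means these few. Any claim that something is new, unique, unknown or untested is made for them only; others in the source may bear on it.

Of the compounds shown here, three sharing one core have been measured in an assay on isolated protein for binding affinity to adenosine receptor A1 (Bos taurus); a higher number here means a weaker inhibitor, a lower number a stronger inhibitor. Compound 1 `Fc1ccccc1Cn1nnc2c(NC3CCCCC3)nc(-c3ccccc3)nc21` gives 1150000 nM. Compound 2 `OC1CCC(Nc2nc(-c3ccccc3)nc3c2nnn3Cc2ccccc2F)CC1`, which adds a hydroxy group on the saturated ring, gives 1850000 nM; the step of a 1.6-fold higher number from compound 1 to compound 2 (0.21 log units; within the scatter) is too small to read as a change. Compound 3 `CCNc1nc(-c2ccccc2)nc2c1nnn2Cc1ccccc1Cl`, which carries an ethylamino group and a chlorine rather than a fluorine on its benzyl ring, gives 463000000 nM. Among these three numbers compound 2 stands second highest, close to compound 1 and far from compound 3.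

Compound 4 `CNc1nc(-c2ccccc2)nc2c1nnn2Cc1ccccc1F` differs from compound 2 in one place: methyl in place of 4-hydroxycyclohexyl on a nitrogen on an aromatic ring. Among the compounds with values here, only one single-place step is available, from compound 1 to compound 2, and it concerns the hydroxy group, not the amine, so it says little here. Within the data shown here, compound 3 is the only measured compound with a small alkyl on that nitrogen, and its number lies far above those of compound 1 and compound 2, though it also differs in its halogen, so two changes are mixed. On that evidence a large step toward a weaker number is expected for compound 4, roughly a 110-fold higher number from compound 2 to compound 4 (2.03 log units; beyond the scatter). Compound 4 is therefore estimated at 200000000 nM, with a likely range from 30000000 nM to 1500000000 nM.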

Compound 4, inhibition constant: 25000000 nM
For compound 4 the middle estimate is 8.0-fold (0.90 log units) above the measured one, outside the stated range (below it).
By their numbers in this assay, from the lowest: compounds 1 and 2 (each within the scatter of the next); then compound 4; then compound 3.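

In this assay, within the data shown here, these steps give the first look at the group on the nitrogen on the aromatic ring with nothing else changing: methyl in place of 4-hydroxycyclohexyl brings a 14-fold higher number from compound 2 to compound 4 (1.13 log units; beyond the scatter) and methyl in place of cyclohexyl brings a 22-fold higher number from compound 1 to compound 4 (1.34 log units; beyond the scatter) in the same direction. Both steps lie beyond the scatter, so among these three compounds the two with a six-membered saturated ring on that nitrogen have the lower numbers, with or without the hydroxy group, and methyl has the higher number. Among these compounds, nothing available here explains why this swap moves the number so far.

The compounds shown leave open how the number changes with other groups on that nitrogen while the fluorine stays in place, such as a propyl chain, a cyclopentyl ring or a plain amine with no carbon group at all. Also open, from the compounds shown here alone, is whether a chlorine in place of the fluorine on the benzyl ring changes the number by itself, a question that compound 3 cannot settle alone.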